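The source may hold more compounds than are shown below. What is called first, only, known or untested is meant among the compounds shown, and "the series" means these compounds.

Measured compounds:
- compound 1, `ClCc1ccc(Cn2cnc3c(Cl)ncnc32)cc1`, gives 7760 nM
- compound 2, `ClCc1ccccc1Cn1cnc2c(Cl)nc(Cl)nc21`, gives 6310 nM
- compound 3, `ClCc1ccc(Cn2cnc3nc(Cl)nc(Cl)c32)cc1`, gives 8910 nM

These three numbers come from a functional assay on NCI-H23 cells (Homo sapiens) for cytotoxicity, read by sulforhodamine B assay, with a stated time of 48 h (a lower number here means that less compound is tolerated, a higher number that more compound is tolerated), and all three lie within the usual scatter of one another, so compound 1 stands level with compound 2 and compound 3 rather than apart from them. Compound 4, `ClCc1ccc(Cn2cnc3c(Cl)nc(Cl)nc32)cc1`, has not yet been measured. It differs from compound 1 in one place: chloro in place of hydrogen on an aromatic carbon. Compound 2 and compound 3 each already carry two chloro groups on the shared core, and their numbers sit within the scatter of compound 1. On that basis no shift beyond the scatter is expected from the added chloro group, and the step of a 1.0-fold lower number from compound 1 to compound 4 (0.01 log units; within the scatter) is estimated to stay within the scatter. Compound 4 is therefore expected to give about 7500 nM in this assay, with a range from 3500 nM to 16000 nM.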

Compound 4, concentration lethal to 50% of the cells: 58900 nM
Beside the measured number, compound 4's estimate is 7.9-fold (0.90 log units) below it, and the stated range ends below it.
By their numbers in this assay, from the lowest: compounds 2, 1 and 3 (each within the scatter of the next); then compound 4.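

Chloro in place of hydrogen on an aromatic carbon, between two ring nitrogen atoms, is the first single change that can be read here: in this assay it gives a 7.6-fold higher number from compound 1 to compound 4 (0.88 log units; beyond the scatter) and so moves the number beyond the scatter. This position is therefore not indifferent to substitution, since one added chlorine atom is enough for more compound to be tolerated. Nothing measured here explains why the number rises.

On these data alone, it remains open whether an amine, a methoxy group or a nitrile on the same carbon would shift the number in the same way, or whether the rise belongs to chloro alone. As far as these compounds go, it is also open whether the same change would have a similar effect in other cell lines.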